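The source may report more compounds than this note shows. Statements on the series, on what has been measured and on what is new or still open speak of the compounds shown alone.

Of the compounds shown here, two sharing the same core have been measured in a functional assay on MCF7 cells (Homo sapiens) for inhibition, read by sulforhodamine B assay; a lower number here means a stronger inhibitor, a higher number a weaker inhibitor. Compound 1 `Cc1ccc(NC2=CC(=O)c3nc4n(c3C2=O)[C@H]2OC[C@@H](O)[C@H]2OC4)cc1` gives 1660 nM in this assay, and compound 2 `O=C1C(Nc2cccc(Cl)c2)=CC(=O)c2c1nc1n2[C@H]2OC[C@@H](O)[C@H]2OC1` gives 2970 nM. Within the data shown here, compound 2 stands at the higher of the two numbers, but its only neighbour, compound 1, sits within the scatter of repeated measurements, so the two values show no ordering between them.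

Compound 3 `O=C1C(NC2CC2)=CC(=O)c2c1nc1n2[C@H]2OC[C@@H](O)[C@H]2OC1` differs from compound 2 in one place: cyclopropyl in place of 3-chlorophenyl on an amine nitrogen. Among the measured compounds shown here, no step between measured compounds speaks to this kind of change, so the measured pair gives no guide to how a cyclopropyl group on that amine nitrogen compares with a 3-chlorophenyl group there. The expectation therefore rests on the change itself rather than on any shown step. The step of a 2.2-fold higher number from compound 2 to compound 3 (0.34 log units; beyond the scatter) is expected to run toward a higher number, that is toward weaker inhibition, by an amount beyond the scatter but not by a great margin. Compound 3 is expected to give about 6500 nM in this assay, with a likely range from 1500 nM to 25000 nM.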

Compound 3, half-maximal inhibitory concentration: > 16000 nM
Compound 3 was reported as a limit; the forecaster's own chance of this, stated with the estimate: 20%; at least 2.4-fold (0.39 log units) between middle value and limit.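

Compound 3 is reported only as a limit in this assay, > 16000 nM, and not as a number. Cyclopropyl in place of 3-chlorophenyl on the amine nitrogen gives an at least 5.3-fold higher number from compound 2 to compound 3 (0.73 log units; beyond the scatter), so this position, on which the earlier compounds offered no step, does respond to the group it carries, and this change costs inhibition by more than the scatter. The size of that step is only a floor, and its reading rests on the limit itself: the limit of > 16000 nM in this assay, at which 1 of the 3 values shown sits.

The compounds shown leave open how far compound 3 really lies past its limit, and whether the loss follows from giving up the six-membered aromatic ring, from giving up the chlorine, or from the smaller group as a whole. A cyclohexyl group or an unsubstituted phenyl on the same amine nitrogen would separate these readings, and how either of them would stand in this assay remains an open question.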